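Alkyl branching at the indole nitrogen in a 5-alpha-reductase series

The compounds below may be only part of what the source reports. "The series", "measured", "known", "first", "only" and "open" are said of these compounds alone.

Measured compounds:
- compound 1 `CCCn1ccc2cc(/C(C)=C/C(=O)Nc3ccccc3OCCCC(=O)O)ccc21`: 190 nM
- compound 2 `CCCC(C)n1ccc2cc(/C(C)=C/C(=O)Nc3ccccc3OCCCC(=O)O)ccc21`: 7.8 nM

Of the compounds shown here, two sharing a common core have been measured in an assay on Prostate gland for inhibition of steroid 5-alpha-reductase (Rattus norvegicus); a higher number here means a weaker inhibitor, a lower number a stronger inhibitor. Compound 1 gives 190 nM in this assay, while compound 2 gives 7.8 nM. Among the compounds with values here, compound 2 therefore holds the lower of the two numbers in this assay, and its only neighbour is compound 1, with a higher number; the step of a 24-fold lower number from compound 1 to compound 2 (1.39 log units; beyond the scatter) is beyond the scatter.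

Compound 3 `CCCC(CC)n1ccc2cc(/C(C)=C/C(=O)Nc3ccccc3OCCCC(=O)O)ccc21` has not yet been measured in this assay. It differs from compound 2 by methyl in place of hydrogen on a saturated chain carbon, two bonds along the chain from an aromatic nitrogen. Within the data shown here, the only measured step bearing on this change is a 24-fold lower number from compound 1 to compound 2 (1.39 log units; beyond the scatter), which also lengthened and branched the substituent on the aromatic nitrogen and gave a large gain. Among the measured compounds shown here, the present change is smaller in extent, so a further step in the same direction is plausible but not assured; no second step is available to check whether the gain continues.

Compound 3 is expected to give about 5 nM in this assay, within 1.5 nM to 20 nM. The expected step of a 1.6-fold lower number from compound 2 to compound 3 (0.19 log units; within the scatter) is modest and may fall within the scatter.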

Compound 3, half-maximal inhibitory concentration: 9.3 nM
Compound 3: middle estimate off by 1.9-fold (0.27 log units), on the low side; measured number inside the range.
By their numbers in this assay, from the lowest: compounds 2 and 3 (each within the scatter of the next); then compound 1.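

In this assay, ethyl in place of methyl on the branch, which turns 1-methylbutyl into 1-ethylbutyl, gives a step within the scatter (a 1.2-fold higher number from compound 2 to compound 3 (0.08 log units; within the scatter)). Within the data shown here, this saturated chain carbon bound to the aromatic nitrogen therefore carries either branch with no readable difference, so the series shows a first sign of a plateau that the single earlier step could not show. The large gain over the unbranched propyl group stands for both branched compounds, at a 24-fold lower number from compound 1 to compound 2 (1.39 log units; beyond the scatter) and at a 20-fold lower number from compound 1 to compound 3 (1.31 log units; beyond the scatter), while no measurement is at hand that bears on the reason for the flat step between them.

The compounds shown leave open whether the gain over propyl comes from the branch or from the added chain length, since both changed together in each large step, and a straight butyl or pentyl group or a smaller branched isopropyl group on the aromatic nitrogen would separate the two. They also leave open how far the plateau extends, for instance to a longer branch such as 1-propylbutyl or to a ring such as cyclopentyl at the same place.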